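Heteroaryl exchange on the sulfonamide nitrogen of compound 2

The compounds below may be only part of what the source reports. "The series", "measured", "known", "first", "only" and "open" are said of these compounds alone.

Of the compounds shown here, three have been measured in a functional assay on NCI-H460 cells (Homo sapiens) for antiproliferative activity, read by sulforhodamine B assay, with a stated time of 72 h; on this read-out higher numbers stand for weaker inhibition and lower numbers for stronger inhibition. Compound 1 `Clc1ccc(C(/C=C/c2ccccc2)=N\Nc2nncc3ccccc23)cc1` gives 9.6 nM. Compound 2 `Cc1cc(NS(=O)(=O)c2ccc(Nc3nncc4ccccc34)cc2)no1` gives 28 nM. Compound 3 `COc1ccc(NC(=S)NNc2nncc3ccccc23)cc1` gives 39 nM. Among these, compound 2 stands second highest of the three numbers: the gap to compound 3 lies within the usual scatter and allows no ordering of the two, whereas compound 1 sits beyond the scatter at a lower number, so compound 1 is the clearly stronger inhibitor of the set.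

Compound 4 `O=S(=O)(Nc1nccs1)c1ccc(Nc2nncc3ccccc23)cc1` has not yet been measured. It differs from compound 2 in one place: 1,3-thiazol-2-yl in place of 5-methyl-1,2-oxazol-3-yl on a sulfonamide nitrogen. The sulfonamide itself, its aryl ring and the rest of the shared core are unchanged.

Among the compounds with values here, no measured pair in this set isolates a change of this kind, so the size of the step rests on judgement alone. A five-membered aromatic ring with two hetero atoms is exchanged for another of the same description, with donors and acceptors counted the same, and the expected step is none beyond the scatter in either direction. The estimated step of a 1.1-fold higher number from compound 2 to compound 4 (0.03 log units; within the scatter) is accordingly set close to zero. On that basis compound 4 is expected to give 30 nM in this assay, with a range of 12 nM to 75 nM.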

Compound 4, half-maximal inhibitory concentration: 39 nM
Compound 4: the middle estimate sits 1.3-fold (0.11 log units) below what was measured; the range from low to high includes it.
By their numbers in this assay, from the lowest: compound 1; then compounds 2, 3 and 4 (each within the scatter of the next).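

Exchange of 5-methyl-1,2-oxazol-3-yl for 1,3-thiazol-2-yl on the sulfonamide nitrogen gives, in this assay, the first step read at this position: a 1.4-fold higher number from compound 2 to compound 4 (0.14 log units; within the scatter). Compound 2 and compound 4 therefore cannot be ordered, and in this assay the sulfonamide nitrogen accepts either of these two five-membered aromatic rings, which differ in their hetero atoms and in the heavy-atom count of the group, without a change that can be told from the scatter. No measurement in hand bears on this result, and the step stays unexplained.

Within the data shown here, this single pair covers only two rings of one description with the same counts of donors and acceptors, so it does not show how far the position stays this forgiving once the group on the sulfonamide nitrogen departs from that description. Open, from the compounds shown here alone, are a plain phenyl ring, a longer alkyl chain, a group carrying a carboxylic acid or an amine, and the bare sulfonamide with only hydrogen on that nitrogen, any of which could show whether the group there matters at all for this read-out.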